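Series notes: from compound 3 to compound 4

The source may hold more compounds than are shown below. What is called first, only, known or untested is meant among the compounds shown, and "the series" means these compounds.

Compound 1 `O=C1c2ccccc2C(=O)N1c1cccc([N+](=O)[O-])c1` is recorded in a functional assay on NUGC cells (Homo sapiens) for cytotoxicity, read by MTT assay, with a stated time of 24 h (on this read-out lower numbers stand for stronger inhibition and higher numbers for weaker inhibition), only as a limit, > 200000 nM. Compound 2 `O=C1c2ccccc2C(=O)N1c1ccc(-c2ccccc2)cc1` likewise reaches only a limit in this assay, > 200000 nM. Compound 3 `Cc1ccc2c(c1)C(=O)N(c1ccc(-c3ccccc3)cc1)C2=O` has no result in this assay, reported as "not determined" (no result reported). Compound 3 therefore stands at no single number; the two further values shown for the series are both limits, namely (the limit of > 200000 nM in this assay, at which 2 of the 3 values shown sit), so the shared core with these aryl substituents has not yet given a measurable half-maximal inhibitory concentration here.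

Compound 4 `Cc1ccc2c(c1)C(=O)N(c1ccc(/N=N\c3ccccc3)cc1)C2=O` differs from compound 3 by a group of 8 heavy atoms (6 carbon, 2 nitrogen; one six-membered aromatic ring of carbon only) in place of a group of 6 heavy atoms (6 carbon; one six-membered aromatic ring of carbon only), on an aromatic carbon, in words a group of 8 heavy atoms (6 carbon, 2 nitrogen; one six-membered aromatic ring of carbon only) in place of a group of 6 heavy atoms (6 carbon; one six-membered aromatic ring of carbon only), on an aromatic carbon. Going by the values given here, no step between measured compounds exists, so no size or direction can be read from measured pairs; with compound 1 at > 200000 nM and compound 2 at > 200000 nM, the expectation in this assay is a weak value, with any shift from compound 3 unlikely to be resolved beyond the scatter. Compound 4 is estimated at 150000 nM, within 30000 nM to 400000 nM.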

Compound 4, half-maximal inhibitory concentration: > 200000 nM
Compound 4 gave a limit, no number (the forecaster's own chance of this, stated with the estimate: 55%); middle value at least 1.3-fold (0.12 log units) away from the limit.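

In this assay compound 4 reaches only a limit, > 200000 nM. Going by these compounds alone, compound 3 carries no number, so no step between compound 3 and compound 4 can be read. The series stays at one limit: the limit of > 200000 nM in this assay, at which 3 of the 4 values shown sit.

The compounds shown leave open whether this shared core can give a measurable half-maximal inhibitory concentration here.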